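The compounds below may be only part of what the source reports. "The series", "measured", "known", "first", "only" and "open" are said of these compounds alone.

Within the data shown here, in a functional assay on HCT-116 cells (Homo sapiens) for antiproliferative activity, read by MTT assay, with a stated time of 72 h (a higher number here means a weaker inhibitor, a lower number a stronger inhibitor), compound 1 `C=CC/N=C1\S/C(=C\c2ccc(OC)cc2)C(=O)N1C` gives 79300 nM, the only number among the three measured compounds. Compound 2 `COc1ccc(/C=C2\S/C(=N\c3cc(C(F)(F)F)cc(C(F)(F)F)c3)N(C)C2=O)cc1` returns only a limit, > 100000 nM. Compound 3 `C=CC/N=C1/NCC(=C)S1` also returns only a limit, > 100000 nM. Compound 4 `COc1ccc(/C=C2\S/C(=N\c3c(C)cccc3C)N(C)C2=O)cc1` keeps the core of compound 1 but carries 2,6-dimethylphenyl in place of allyl on a double-bonded nitrogen. Among the measured compounds shown here, no measured step isolates this change. Compound 2 also has a six-membered aromatic ring on that nitrogen and gives the limit > 100000 nM, so in this assay no step beyond the scatter is expected, with a slight lean towards weaker inhibition. The expected step is a 1.1-fold higher number from compound 1 to compound 4 (0.03 log units; within the scatter). Compound 4 is estimated at 85000 nM, with an expected range of 30000 nM to 150000 nM.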

Compound 4, half-maximal inhibitory concentration: > 100000 nM
Compound 4 gave a limit, no number; the forecaster's own chance of this, stated with the estimate: 50%; middle value at least 1.1-fold (0.07 log units) away from the limit.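

In this assay, among these compounds, 2,6-dimethylphenyl in place of allyl on a double-bonded nitrogen gives an at least 1.2-fold higher number from compound 1 to compound 4 (0.10 log units; that floor lies within the scatter), the first direct reading of a change at this position. Compound 4, like compound 2, carries a six-membered aromatic ring on that nitrogen, and neither returns a number. The value of compound 4 is a limit, so this step is only a floor, and compound 4 joins the values that mark the end of the readable range: the limit of > 100000 nM in this assay, at which 3 of the 4 values shown sit.

As far as these compounds go, how far compound 4 actually lies from compound 1 stays open. So does how a carboxylic acid or a longer chain on that nitrogen would read in this assay.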